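The compounds below may be only part of what the source reports. "The series", "measured", "known", "first", "only" and "open" are said of these compounds alone.

Three compounds share one core and differ only in a group on a phenyl ring. Compound 1 `CCOc1nc(-c2cc3ccccc3o2)cc(-c2ccccc2)c1C#N` gives 310000 nM in a functional assay on aorta (strain Wistar) for inhibition, with Thoracic aorta (Rattus norvegicus) as the target; on this read-out higher numbers stand for weaker inhibition and lower numbers for stronger inhibition. Compound 2 `CCOc1nc(-c2cc3ccccc3o2)cc(-c2ccc(Cl)cc2)c1C#N` gives 221000 nM. Compound 3 `CCOc1nc(-c2cc3ccccc3o2)cc(-c2ccc(C)cc2)c1C#N` gives 290000 nM, the second highest of the three numbers: its nearest neighbour is compound 1, its furthest compound 2, and both gaps lie within the scatter.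

Compound 4 `CCOc1nc(-c2cc3ccccc3o2)cc(-c2ccc(N(C)C)cc2)c1C#N` is not yet measured. It differs from compound 3 by dimethylamino in place of methyl on an aromatic carbon.

Within the data shown here, two measured steps touch the same aromatic carbon. The change from hydrogen to methyl gave a 1.1-fold lower number from compound 1 to compound 3 (0.03 log units; within the scatter), and the change from chloro to methyl gave a 1.3-fold higher number from compound 2 to compound 3 (0.12 log units; within the scatter). Neither left the scatter, so this position has so far tolerated three different groups without a shift. On that basis the step to a dimethylamino group is expected to be no change at the digits printed from compound 3 to compound 4 (within the scatter), with no direction beyond the scatter. Compound 4 is therefore estimated at 290000 nM, with a range from 120000 nM to 700000 nM.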

Compound 4, half-maximal inhibitory concentration: 338000 nM
Beside the measured number, compound 4's estimate is 1.2-fold (0.07 log units) below it; the range from low to high includes it.
By their numbers in this assay, from the lowest: compounds 2, 3, 1 and 4 (each within the scatter of the next).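

In this assay, the dimethylamino group also stays within the scatter, with a 1.2-fold higher number from compound 3 to compound 4 (0.07 log units; within the scatter), a 1.5-fold higher number from compound 2 to compound 4 (0.18 log units; within the scatter) and a 1.1-fold higher number from compound 1 to compound 4 (0.04 log units; within the scatter). Among these compounds, this is the first group at this aromatic carbon to bring in nitrogen and a hydrogen-bond acceptor, and it has three heavy atoms where methyl has one, yet the number does not leave the scatter against any of the three earlier compounds. Nothing available explains why this carbon accepts such different groups with so little change.

The compounds shown leave open whether a carboxylic acid or a longer chain on this same carbon would move the number beyond the scatter. Going by these compounds, they also vary nothing else, so the part played by the rest of the shared core remains unknown.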